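This account rests on a few compounds, and the source may have more. Where it says the series, first, only, none or still open, it means among the compounds named here.

Measured so far:
Compound 1 `CC(C)N1CCN(CCN2CCC(c3c[nH]c4cc(Cl)ccc34)CC2)C1=O`: 34 nM
Compound 2 `CC(C)N1CCN(CCN2CCC(c3cn(-c4ccccc4)c4cc(Cl)ccc34)CC2)C1=O`: 39 nM

In an assay on cell membranes for displacement of a labelled ligand from Adrenergic receptor alpha-1 (Rattus norvegicus) (a higher number here means a weaker inhibitor, a lower number a stronger inhibitor), compound 2 gives 39 nM, and compound 1 gives 34 nM; the two sit within the scatter of each other, so neither can be separated from the other. Among the compounds with values here, the only measured step, a 1.1-fold higher number from compound 1 to compound 2 (0.06 log units; within the scatter), shows that adding a phenyl on the aromatic nitrogen left the number essentially unchanged.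

Compound 3 `CC(C)N1CCN(CCN2CCC(c3cn(-c4ccccc4F)c4cc(Cl)ccc34)CC2)C1=O` differs from compound 2 by fluoro in place of hydrogen on an aromatic carbon. Within the data shown here, no measured step tests this kind of change, so the expectation rests on the unchanged number seen so far: the step is estimated as a 1.0-fold higher number from compound 2 to compound 3 (0.01 log units; within the scatter), with no change beyond the scatter. Compound 3 is therefore expected at about 40 nM, with a range from 15 nM to 110 nM.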

Compound 3, half-maximal inhibitory concentration: 120 nM
Beside the measured number, compound 3's estimate is 3.0-fold (0.48 log units) below it, and the stated range ends below it.
By their numbers in this assay, from the lowest: compounds 1 and 2 (each within the scatter of the next); then compound 3.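

A phenyl on the aromatic nitrogen changed nothing beyond the scatter, but adding one fluoro on that phenyl, ortho to a large group, gives a 3.1-fold higher number from compound 2 to compound 3 (0.49 log units; beyond the scatter) in this assay and shows that this ring does respond to substitution. Measured against hydrogen on that nitrogen, the 2-fluorophenyl group gives a 3.5-fold higher number from compound 1 to compound 3 (0.55 log units; beyond the scatter) even though plain phenyl stayed within the scatter. The compounds shown leave open whether a larger group such as chloro or methoxy at this place would raise the number further, or whether fluoro is a special case. No measured evidence here explains the shift.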